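This account rests on a few compounds, and the source may have more. Where it says the series, first, only, none or still open, it means among the compounds named here.

Three compounds were measured in a functional assay on A-431 cells (Homo sapiens) for cytotoxicity, read by MTT assay, with a stated time of 72 h, tested at 100 uM; on this read-out higher numbers stand for more inhibition of growth at the one concentration tested and lower numbers for less inhibition of growth. Compound 1 `N/C(=N\NC(=S)N1CCCCC1)c1ccccn1` gives 85.6%. Compound 2 `Cc1cccc(/C(N)=N/NC(=S)N2CCCCC2)n1`, which carries a methyl on the aromatic ring, gives 77.5%. Compound 3 `Cc1cccc(/C(N)=N/NC(=S)N2CCCC2)n1`, with a pyrrolidin-1-yl on the thiocarbonyl carbon instead of a piperidin-1-yl, gives 86.8%. Removing the methyl from compound 2 gave a number 8.1 percentage points higher from compound 2 to compound 1 (within the scatter); the change is hydrogen in place of methyl on an aromatic carbon. Swapping the saturated ring gave a number 9.3 percentage points higher from compound 2 to compound 3 (within the scatter); that change is pyrrolidin-1-yl in place of piperidin-1-yl on a thiocarbonyl carbon, and it is also how the core of compound 3 differs from the core of compound 2.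

Compound 4 `N/C(=N\NC(=S)N1CCCC1)c1ccccn1` has not yet been measured. For the measured compounds named here, it arises from compound 3 by hydrogen in place of methyl on an aromatic carbon, the same change as the one from compound 2 to compound 1, at the same place. Because compound 2 gave a number 8.1 percentage points higher from compound 2 to compound 1 (within the scatter) on losing its methyl, a step of similar small size is expected here, expressed as a number 3.2 percentage points higher from compound 3 to compound 4 (within the scatter), tempered by compound 3 already standing near the top of the scale. Compound 4 is therefore expected to give about 90%, most likely between 79% and 98%.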

Compound 4, percent growth inhibition at one concentration: 83.8%
Beside the measured number, compound 4's estimate is 6.2 percentage points above it; the measured number falls inside the stated range.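

Hydrogen in place of methyl on an aromatic carbon gave a number 3 percentage points lower from compound 3 to compound 4 (within the scatter) in this assay, and this step cannot be told apart from the earlier one: the same change on two cores in this assay, a number 8.1 percentage points higher (within the scatter) from compound 2 to compound 1 and a number 3 percentage points lower (within the scatter) from compound 3 to compound 4, 11.1 percentage points apart, within the scatter of two such steps. Pyrrolidin-1-yl in place of piperidin-1-yl on a thiocarbonyl carbon gave a number 1.8 percentage points lower from compound 1 to compound 4 (within the scatter), and the same holds for this change: the same change on two cores in this assay, a number 9.3 percentage points higher (within the scatter) from compound 2 to compound 3 and a number 1.8 percentage points lower (within the scatter) from compound 1 to compound 4, 11.1 percentage points apart, within the scatter of two such steps. So neither change can be said to behave differently on the two cores, but with every step inside the scatter, these four compounds do not show that either change has a real effect, or that any effect carries from one core to another.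

The compounds shown leave open what an amine, a methoxy group or a chlorine would do in place of the methyl on the aromatic carbon. They also leave open whether a morpholin-4-yl group or an open diethylamino group on the thiocarbonyl carbon would give a step larger than the scatter.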